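Methyl for fluoro on the benzylic ring, compound 4

The compounds below may be only part of what the source reports. "The series", "measured", "known", "first", "only" and "open" are said of these compounds alone.

Of the compounds shown here, three have been measured in an assay on Sf9 cells for inhibition of Amine oxidase [flavin-containing] A (Homo sapiens), with stated times of 15 min and 60 min; a higher number here means a weaker inhibitor, a lower number a stronger inhibitor. Compound 3 `NC(=O)[C@@H]1CCN1Cc1ccc(OCc2cccc(F)c2)cc1F` gives 18600 nM in this assay. Compound 1 `Cc1cc(OCc2cccc(F)c2)ccc1CN1CC[C@H]1C(N)=O` gives 8650 nM in this assay. The two differ in one place only, (methyl in place of fluoro on an aromatic carbon), and the step was a 2.2-fold lower number from compound 3 to compound 1 (0.33 log units; beyond the scatter). Compound 2 `C#CCN(Cc1ccc(OCc2cccc(F)c2)cc1F)[C@@H](C)C(N)=O` gives 8710 nM in this assay; the values of compound 2 and compound 1 lie within the scatter of each other, while compound 3 shows a higher number than compound 2. The difference between the core of compound 2 and the core of compound 3 is not broken down here.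

Compound 4 `C#CCN(Cc1ccc(OCc2cccc(F)c2)cc1C)[C@@H](C)C(N)=O` has not been measured. It differs from compound 2 by methyl in place of fluoro on an aromatic carbon. This is the same kind of change as that from compound 3 to compound 1, not the same one: in compound 3 the carbon is ortho to a (2-carbamoylazetidin-1-yl)methyl group (8 heavy atoms), whereas in compound 2 it is ortho to a large group. A modest lowering is expected from compound 2 to compound 4 in this assay, a 1.9-fold lower number from compound 2 to compound 4 (0.29 log units; within the scatter), because a 2.2-fold lower number from compound 3 to compound 1 (0.33 log units; beyond the scatter) went beyond the scatter with the same change. Compound 4 is therefore estimated at 4500 nM, expected to fall between 2000 nM and 11000 nM.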

Compound 4, half-maximal inhibitory concentration: 6400 nM
For compound 4 the middle estimate is 1.4-fold (0.15 log units) below the measured one; the range from low to high includes it.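

In this assay the replacement of fluoro by methyl gave a 1.4-fold lower number from compound 2 to compound 4 (0.13 log units; within the scatter), a step that taken alone cannot be told apart from no change. Set beside the step on the other core, it does not differ by more than two such steps are expected to differ: the same change on two cores in this assay, a 2.2-fold lower number (0.33 log units; beyond the scatter) from compound 3 to compound 1 and a 1.4-fold lower number (0.13 log units; within the scatter) from compound 2 to compound 4, 1.6-fold (0.20 log units) apart, within the scatter of two such steps. Among these compounds, this shows that the two cores give compatible results for this change, but it does not establish a transferable effect of fixed size: only the step on the core of compound 3 stands beyond the scatter, and two cores are a narrow basis for any rule across the series.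

Still open, from the compounds shown here alone, is whether another group on the same aromatic carbon, such as chloro or methoxy, would fit with methyl and fluoro. Also open, going by these compounds, is whether the step would persist on a core carrying a carboxylic acid in place of the amide, or a longer chain on the ring nitrogen's counterpart in compound 2.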